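The compounds below may be only part of what the source reports. "The series", "measured", "known", "first", "only" and "open" are said of these compounds alone.

Measured compounds:
compound 1, `FC(F)(F)c1cccc(Nc2ncnc3sc(Nc4c(Cl)cccc4Cl)nc23)c1`, with 206 nM in a functional assay on HEK293 cells for antagonist activity at transient receptor potential cation channel subfamily V member 1 (Homo sapiens), read by calcium flux; a lower number here means a stronger inhibitor, a higher number a weaker inhibitor
compound 2, `FC(F)(F)c1ccc(Nc2nc(N3CCC3)nc3sc(Nc4c(Cl)cccc4Cl)nc23)cc1`, with 59 nM in this assay

Compound 2 stands at the lower of the two numbers in this assay, and compound 1 sits higher by a margin that goes beyond the usual scatter of repeated measurements. The two compounds differ in more than one place, so their gap is not broken down further here.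

Compound 3, `CC(C)CNc1nc(Nc2ccc(C(F)(F)F)cc2)c2nc(Nc3c(Cl)cccc3Cl)sc2n1`, has not yet been tested in this assay. It differs from compound 2 in one place: isobutylamino in place of azetidin-1-yl on an aromatic carbon. Among the compounds with values here, no measured pair shows the effect of this exchange, so the direction is open. The expectation for compound 3 is a step from compound 2 of a 1.3-fold higher number from compound 2 to compound 3 (0.10 log units; within the scatter), which is not beyond the scatter. Compound 3 is therefore estimated at 75 nM, with a range from 25 nM to 220 nM in this assay.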

Compound 3, half-maximal inhibitory concentration: 2 nM
For compound 3 the middle estimate is 38-fold (1.57 log units) above the measured one; the measured number lies below the stated range.
By their numbers in this assay, from the lowest: compound 3; then compound 2; then compound 1.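

On the aromatic carbon between two ring nitrogen atoms, isobutylamino in place of azetidin-1-yl gives a 30-fold lower number from compound 2 to compound 3 (1.47 log units; beyond the scatter) in this assay. Within the data shown here, this is the first exchange that can be read at a single place, and it shows that the group on this carbon can move the number far beyond the scatter. The exchange opens the four-membered ring into a chain and adds a hydrogen-bond donor, but no measurement here accounts for the size of the step.

The two compounds do not separate the effect of the amine hydrogen from that of the open isobutyl chain. Going by these compounds, a dimethylamino group, a cyclobutylamino group or a longer chain such as n-pentylamino on this carbon remains open, as does whether the step carries over to other groups on the shared core.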